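An aryl swap on a weak growth inhibitor

The compounds below may be only part of what the source reports. "The series", "measured", "known", "first", "only" and "open" are said of these compounds alone.

In a functional assay on DU-145 cells (Homo sapiens) for inhibition, read by trypan blue exclusion, with a stated time of 96 h (a higher number here means a weaker inhibitor of growth, a lower number a stronger inhibitor of growth), compound 1 (`Nc1c(Br)cc(Br)cc1/C=C(/Sc1ccc(Br)cc1)C(=O)c1ccc(Br)cc1`) gives > 100000 nM as its reading, a limit of the assay and not a number. Among the measured compounds shown here, compound 2 (`COc1ccc(/C=C(/Sc2ccc(Br)cc2)C(=O)c2ccc(Br)cc2)c(F)c1`) stands at 20000 nM as the only actual number so far. Compound 3 (`O=C(/C(=C\c1ccc(F)cc1Cl)Sc1ccc(Br)cc1)c1ccc(Br)cc1`) carries 2-chloro-4-fluorophenyl in place of 2-fluoro-4-methoxyphenyl on a double-bonded chain carbon bound to a double-bonded chain carbon. For the measured compounds named here, the one measured step at that place is an at least 5.0-fold lower number from compound 1 to compound 2 (0.69 log units; beyond the scatter) and it lies beyond the scatter. Here only a small step is expected (a 1.3-fold lower number from compound 2 to compound 3 (0.12 log units; within the scatter)) and none clearly beyond the scatter. Compound 3 is expected to lie at 15000 nM (estimated range 4000 nM to 60000 nM).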

Compound 3, concentration for 50% growth inhibition: 1000 nM
Compound 3: the middle estimate sits 15-fold (1.18 log units) above what was measured; measured number outside the range, below it.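

The aryl group on the double-bonded chain carbon matters far more in this assay than the earlier pair could show: 2-chloro-4-fluorophenyl in place of 2-fluoro-4-methoxyphenyl gives a 20-fold lower number from compound 2 to compound 3 (1.30 log units; beyond the scatter). Against 2-amino-3,5-dibromophenyl, the same group gives an at least 100-fold lower number from compound 1 to compound 3 (2.00 log units; beyond the scatter). That second step is open-ended, as compound 1 stands at a limit of the assay and not at a number: the limit of > 100000 nM in this assay, at which 1 of the 3 values shown sits.

The entering and leaving rings differ in both substituents at once, so the compounds shown do not say which one carries the gain. Going by these compounds, whether a nitrile or a trifluoromethyl group on that ring would keep it also remains open.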